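The source may hold more compounds than are shown below. What is called first, only, known or untested is meant among the compounds shown, and "the series" means these compounds.

In a functional assay on PANC-1 cells (Homo sapiens) for antiproliferative activity, read by fluorescence and resazurin assay, with a stated time of 48 h (a higher number here means a weaker inhibitor, a lower number a stronger inhibitor), compound 1 (`CCOc1ccc(NC(=O)c2cc3cc(Br)ccc3oc2=O)cc1`) gives 16800 nM and compound 2 (`Cc1noc(NS(=O)(=O)c2ccc(NC(=O)c3cc4cc([N+](=O)[O-])ccc4oc3=O)cc2)c1C`) gives 11900 nM as its value, so compound 2 stands level with compound 1, the two numbers lying within the scatter of each other. Among the compounds with values here, no step between measured compounds that differ in one place is available. Compound 3 (`CCOc1ccc(NC(=O)c2cc3cc([N+](=O)[O-])ccc3oc2=O)cc1`) differs from compound 2 by one change (ethoxy in place of (3,4-dimethyl-1,2-oxazol-5-yl)sulfamoyl on an aromatic carbon) in which ethoxy takes the place of (3,4-dimethyl-1,2-oxazol-5-yl)sulfamoyl on an aromatic carbon. Ethoxy already stands on compound 1 at 16800 nM in the same range as compound 2 at 11900 nM so no shift beyond the scatter is expected in this assay for this change. The estimated size of the step is a 1.2-fold higher number from compound 2 to compound 3 (0.07 log units; within the scatter) and stays within the scatter. For compound 3 the expected value is 14000 nM within an estimated range from 6000 nM to 32000 nM in this series.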

Compound 3, half-maximal inhibitory concentration: 12100 nM
Beside the measured number, compound 3's estimate is 1.2-fold (0.06 log units) above it; the measured number falls inside the stated range.
By their numbers in this assay, from the lowest: compounds 2, 3 and 1 (each within the scatter of the next).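

In this assay, ethoxy in place of (3,4-dimethyl-1,2-oxazol-5-yl)sulfamoyl gives a 1.0-fold higher number from compound 2 to compound 3 (0.01 log units; within the scatter) and stays within the scatter, so at this aromatic carbon, para to a large group, a substituent of 11 heavy atoms carrying a five-membered aromatic ring and one of 3 heavy atoms with no ring read alike. Within the data shown here, compound 3 also gives a first comparison with ethoxy held fixed: nitro in place of bromo on an aromatic carbon gives a 1.4-fold lower number from compound 1 to compound 3 (0.14 log units; within the scatter) and likewise stays within the scatter. Nothing available explains why these numbers agree.

On these data alone, whether an amine, a carboxylic acid or a longer alkoxy chain at the ethoxy position would leave the number in this range stays open. Also open, as far as these compounds go, is whether bromo and nitro would read alike alongside (3,4-dimethyl-1,2-oxazol-5-yl)sulfamoyl, which appears here only with nitro.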